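Iodo on the phenyl ring of compound 2

This account rests on a few compounds, and the source may have more. Where it says the series, first, only, none or still open, it means among the compounds named here.

Working notes on the series. In a functional assay on A549 cells (Homo sapiens) for antiproliferative activity, read by sulforhodamine B assay, with a stated time of 48 h (on this read-out lower numbers stand for stronger inhibition of growth and higher numbers for weaker inhibition of growth), compound 1 (`Cc1cc2c(cc1C)C(Cl)=C(C(=O)NNC(=S)Nc1ccccc1)CCC2`) gives 759 nM, compound 2 (`Cc1cc2c(cc1C)C(Cl)=C(c1nnc(-c3ccccc3)o1)CCC2`) gives 1960 nM, and compound 3 (`COc1cc(-c2nnc(C3=C(Cl)c4cc(C)c(C)cc4CCC3)o2)cc(OC)c1OC`) gives 1260 nM. Compound 2 lies within the scatter of compound 3 and beyond the scatter of compound 1, whose number is lower.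

Compound 4 (`Cc1cc2c(cc1C)C(Cl)=C(c1nnc(-c3cccc(I)c3)o1)CCC2`) has not yet been measured. It differs from compound 2 by iodo in place of hydrogen on an aromatic carbon, meta to a large group, turning phenyl into 3-iodophenyl: iodo in place of hydrogen on an aromatic carbon.

Among the measured compounds shown here, no measured pair isolates this change. The nearest guide is compound 3, which also carries substituents on this phenyl and, at 1260 nM, stays within the scatter of compound 2. The expected result in this assay is therefore a small move toward a lower number, a 1.3-fold lower number from compound 2 to compound 4 (0.12 log units; within the scatter), not beyond the scatter.

Compound 4 is estimated at 1500 nM, with an expected range of 650 nM to 3400 nM.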

Compound 4, concentration for 50% growth inhibition: 2780 nM
Beside the measured number, compound 4's estimate is 1.9-fold (0.27 log units) below it, and the stated range covers the measured number.
By their numbers in this assay, from the lowest: compounds 1, 3, 2 and 4 (each within the scatter of the next, the first and the last beyond it).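

In this assay, among the compounds shown here, a 1.4-fold higher number from compound 2 to compound 4 (0.15 log units; within the scatter) gives the first reading of a single change on this phenyl ring: 3-iodophenyl in place of phenyl stays within the scatter. A single heavy atom, iodo, on an aromatic carbon, meta to a large group, therefore leaves the number where it was, something compound 3 could not show, as it differs from compound 2 in more than one place. No measurement at hand bears on why this change leaves the number unmoved.

Open, going by these compounds, is whether an amine or a carboxylic acid in place of iodo at this same carbon would give a step beyond the scatter. Also open, on these data alone, is whether iodo on another carbon of this phenyl ring would read as compound 4 does.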